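The source may hold more compounds than are shown below. What is called first, only, known or untested is meant among the compounds shown, and "the series" means these compounds.

In a functional assay on K562 cells (Homo sapiens), read by MTT assay, with a stated time of 72 h (a lower number here means a stronger inhibitor, a higher number a weaker inhibitor), two nucleosides with closely related structures have been measured. Compound 1 (`C#Cc1cn([C@@H]2O[C@H](CO)[C@@H](O)[C@H]2O)c2ncnc(OC)c12`) gives 300 nM and compound 2 (`Cc1ncnc2c1c(-c1ccsc1)cn2[C@@H]1O[C@H](CO)[C@@H](O)[C@H]1O`) gives 320 nM, so the two values lie within the usual scatter of each other. Compound 2 therefore stands level with compound 1 on these numbers. Compound 3 (`C#Cc1cn([C@@H]2O[C@H](CO)[C@@H](O)[C@H]2O)c2ncnc(C)c12`) follows from compound 2 by one change, ethynyl in place of thiophen-3-yl on an aromatic carbon. For the measured compounds named here, no measured pair shows this change on its own. However, the ethynyl group also occurs in compound 1, which gives 300 nM. A step beyond the scatter in this assay is therefore not expected, in either direction. The estimated change is a 1.3-fold lower number from compound 2 to compound 3 (0.11 log units; within the scatter). For compound 3 the expected value is 250 nM, within an estimated range of 80 nM to 800 nM.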

Compound 3, half-maximal inhibitory concentration: 6920 nM
The estimate for compound 3 lay 28-fold (1.44 log units) below the measured number; measured number outside the range, above it.
By their numbers in this assay, from the lowest: compounds 1 and 2 (each within the scatter of the next); then compound 3.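

In this assay, the position on the five-membered aromatic ring proves sensitive to this change when methyl is the other group on the core: ethynyl in place of thiophen-3-yl gives a 22-fold higher number from compound 2 to compound 3 (1.33 log units; beyond the scatter). Methyl in place of methoxy, with ethynyl kept, gives a 23-fold higher number from compound 1 to compound 3 (1.36 log units; beyond the scatter), so a low number with ethynyl is not a feature of that group alone: it holds alongside methoxy and is lost alongside methyl. Nothing available explains the size of either step.

The compounds shown leave open how thiophen-3-yl behaves alongside methoxy, so it cannot be said whether that group also depends on its partner. They also leave open whether an amine in place of methyl would bring back a low number with ethynyl, and how a longer chain in place of ethynyl would fare.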